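The compounds below may be only part of what the source reports. "The series", "measured", "known", "first", "only" and "open" are said of these compounds alone.

Measured in an in vitro assay on FRT cells with Cystic fibrosis transmembrane conductance regulator variant F508del (Homo sapiens) as the target, read by fluorescence, with a stated time of 24 h, at 37 degrees C, in the presence of a further agent that is not named here; on this read-out higher numbers stand for an effect only at larger amounts of compound and lower numbers for an effect already at smaller amounts:
- compound 1 `COc1ccc(C(=O)NCCNc2nc3cc(C)cc(C)c3cc2C#N)cc1`: 3000 nM
- compound 2 `Cc1cc(C)c2cc(C#N)c(NCCNC(=O)c3ccccn3)nc2c1`: "not active" (no number reported)
- compound 3 `Cc1cc(C)c2cc(C#N)c(NCCNC(=O)c3cnccn3)nc2c1`: 6700 nM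

Compound 3 carries the highest number of the two reported in this assay; its nearest neighbour is compound 1, and compound 2 returned no number. Among the measured compounds shown here, the one step that bears on the carbonyl-side aryl group is a 2.2-fold higher number from compound 1 to compound 3 (0.35 log units; beyond the scatter), a modest shift. Compound 4 `COc1cccc(OC)c1C(=O)NCCNc1nc2cc(C)cc(C)c2cc1C#N` changes (2,6-dimethoxyphenyl in place of pyrazin-2-yl on a carbonyl carbon). Since compound 1 with a carbon-only ring gives 3000 nM, a dimethoxy-substituted carbon-only ring is expected to return toward that level, with a step of a 1.9-fold lower number from compound 3 to compound 4 (0.28 log units; within the scatter). For compound 4 the estimate in this assay is 3500 nM, within 1200 nM to 10000 nM.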

Compound 4, half-maximal effective concentration: 3700 nM
Compound 4: middle estimate off by 1.1-fold (0.02 log units), on the low side; measured number inside the range.
By their numbers in this assay, from the lowest: compounds 1, 4 and 3 (each within the scatter of the next, the first and the last beyond it).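

In this assay, 2,6-dimethoxyphenyl on this carbonyl carbon is tolerated: a 1.2-fold higher number from compound 1 to compound 4 (0.09 log units; within the scatter) leaves it level with 4-methoxyphenyl, and a 1.8-fold lower number from compound 3 to compound 4 (0.26 log units; within the scatter) does not separate it from pyrazin-2-yl either. A second methoxy group on the carbon-only ring therefore brings no measurable gain, and the gap between compound 1 and compound 3 finds no intermediate step beyond the scatter. No supporting data explain this flat result.

From the compounds shown here alone, whether an amine or a carboxylic acid on this ring would shift the number remains open. So does the effect of a longer chain between the amide nitrogen and the core.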